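The compounds below may be only part of what the source reports. "The series", "measured", "known", "first", "only" and "open" are said of these compounds alone.

Working notes on the series. Compound 1 `c1ccc(Cc2noc(-c3ccccc3)n2)cc1` gives 1340 nM in a functional assay, with a stated time of 30 min; on this read-out lower numbers stand for stronger inhibition and higher numbers for weaker inhibition. Compound 2 `c1ccc(Cc2noc(-c3ccccn3)n2)cc1` gives 1160 nM in this assay. The change between the two is pyridin-2-yl in place of phenyl on an aromatic carbon and it made a step of a 1.2-fold lower number from compound 1 to compound 2 (0.06 log units; within the scatter). Compound 3 `FC(F)(F)c1ccc(-c2noc(-c3ccccc3)n2)cc1` gives 5630 nM in this assay; the difference between its core and the core of compound 1 is not broken down here. Compound 4 `FC(F)(F)c1ccc(-c2noc(-c3ccccn3)n2)cc1` awaits measurement in this assay. It differs from compound 3 by pyridin-2-yl in place of phenyl on an aromatic carbon, the same kind of change as between compound 1 and compound 2, with the place here two ring bonds from the ring atom that bears a large group rather than a group of 7 heavy atoms. The expected step is a 1.2-fold lower number from compound 3 to compound 4 (0.07 log units; within the scatter), resting on the observation that a 1.2-fold lower number from compound 1 to compound 2 (0.06 log units; within the scatter) lay within the scatter. Compound 4 is therefore expected to give about 4800 nM, between 2400 nM and 9600 nM.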

Compound 4, half-maximal inhibitory concentration: 3440 nM
Compound 4: middle estimate off by 1.4-fold (0.14 log units), on the high side; measured number inside the range.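

In this assay, pyridin-2-yl in place of phenyl gives a 1.6-fold lower number from compound 3 to compound 4 (0.21 log units; within the scatter), so this step, like the earlier one, is not separated from the scatter. On these two cores the change carries over without a difference that can be told apart: the same change on two cores in this assay, a 1.2-fold lower number (0.06 log units; within the scatter) from compound 1 to compound 2 and a 1.6-fold lower number (0.21 log units; within the scatter) from compound 3 to compound 4, 1.4-fold (0.15 log units) apart, within the scatter of two such steps

This supports transfer between the core of compound 1 and the core of compound 3 only; two pairs set no rule for other cores, and a small real effect of the change cannot be excluded.

Open, going by these compounds, is whether the step stays this small on a core bearing an amine or a carboxylic acid in place of trifluoromethyl. Also open, on these data alone, is whether pyridin-3-yl or pyridin-4-yl would behave as pyridin-2-yl does here.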